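A few compounds are considered here, and "the series" means these few. Any claim that something is new, unique, unknown or untested is made for them only; others in the source may bear on it.

Measured so far:
compound 1 `N=C1S/C(=C\c2ccc(OCc3ccccc3)cc2)C(=O)N1c1ccc(F)cc1` — 10.5%
compound 2 `N=C1S/C(=C\c2ccc(OCc3ccccc3)cc2)C(=O)N1c1ncccn1` — 26.6%

In an ADME assay on RAW264.7 cells (Mus musculus) for cytotoxicity, read by MTT assay, with a stated time of 48 h, tested at 50 uM (on this read-out lower numbers stand for less inhibition and higher numbers for more inhibition at the one concentration tested (going by the name of the read-out)), compound 1 gives 10.5%, the lowest of the two numbers; compound 2 gives 26.6%. Going by the values given here, the single measured step, a number 16.1 percentage points higher from compound 1 to compound 2 (beyond the scatter), changes the group on the amide-type nitrogen in the ring and lies beyond the scatter.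

Compound 3 `Cc1cccc(C)c1N1C(=N)S/C(=C\c2ccc(OCc3ccccc3)cc2)C1=O` has not yet been measured in this assay. It differs from compound 1 by 2,6-dimethylphenyl in place of 4-fluorophenyl on an amide-type nitrogen in a ring. The step from compound 1 to compound 2 is the only one at this position, and it carries a different entering group, so it bears on compound 3 only in part: it shows that a change here can shift the number modestly. Nothing measured shows the effect of 2,6-dimethylphenyl itself. A step within the scatter, or a small one in either direction, is therefore expected.

Compound 3 is estimated at 15%, with a range of 3% to 32%. This means an expected step of a number 4.5 percentage points higher from compound 1 to compound 3 (within the scatter).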

Compound 3, a percentage reported as inhibition, at one concentration (the size of the read-out at that concentration, not a potency): 38.7%
Compound 3: middle estimate off by 23.7 percentage points, on the low side, and the stated range ends below it.
By their numbers in this assay, from the lowest: compound 1; then compound 2; then compound 3.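

In this assay the change to 2,6-dimethylphenyl brings a number 28.2 percentage points higher from compound 1 to compound 3 (beyond the scatter) and, set against pyrimidin-2-yl, a number 12.1 percentage points higher from compound 2 to compound 3 (beyond the scatter) so that the largest number of the three now belongs to a group with a six-membered aromatic ring of carbon only. The number at this position therefore does not follow ring nitrogen in the entering group: compound 1 and compound 3 both carry a carbon-only aromatic ring yet stand at the two ends of the order, with the pyrimidin-2-yl of compound 2 in the middle. No supporting measurement bears on this order.

On these data alone, how an amine or a carboxylic acid on this aromatic ring, or a longer alkyl chain in its place on the amide-type nitrogen, would read in this assay remains open. Also open, as far as these compounds go, is whether the order of these three groups holds when another part of the shared core changes.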